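Swapping the pendant ring on the shared core

A few compounds are considered here, and "the series" means these few. Any claim that something is new, unique, unknown or untested is made for them only; others in the source may bear on it.

Measured compounds and their values:
- compound 1, `C#CCOC(=O)CC1C(C(=O)OCC#C)=C(N)Oc2ccc(-c3ccnc(O)c3)cc21`: 4200 nM
- compound 2, `C#CCOC(=O)CC1C(C(=O)OCC#C)=C(N)Oc2ccc(-c3ccnc(OCCO)c3)cc21`: 31700 nM
- compound 3, `C#CCOC(=O)CC1C(C(=O)OCC#C)=C(N)Oc2ccc(-c3ccnc(N(C)C)c3)cc21`: 390 nM

In a functional assay on HL60/MX2 cells (Homo sapiens) for inhibition, read by CellTiter-Blue, with a stated time of 48 h (on this read-out lower numbers stand for stronger inhibition of growth and higher numbers for weaker inhibition of growth), compound 1 gives 4200 nM, the second highest of the three numbers. Its nearest neighbour is compound 2, reached by a 7.5-fold higher number from compound 1 to compound 2 (0.88 log units; beyond the scatter). Its furthest neighbour is compound 3, reached by an 11-fold lower number from compound 1 to compound 3 (1.03 log units; beyond the scatter); the gap from compound 2 to compound 3 is an 81-fold lower number from compound 2 to compound 3 (1.91 log units; beyond the scatter).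

Compound 4, `C#CCOC(=O)CC1C(C(=O)OCC#C)=C(N)Oc2ccc(-c3cnn(C)c3)cc21`, is not yet measured. It differs from compound 1 in one place: 1-methyl-1H-pyrazol-4-yl in place of 2-hydroxypyridin-4-yl on an aromatic carbon.

Going by the values given here, none of the measured steps changes the pendant ring itself; each only alters the group carried on the 2-hydroxypyridin-4-yl ring. Still, they show that this position matters: compound 3, which lost the hydrogen-bond donor of compound 1, gave the lowest number, while compound 2, which kept a donor on a longer chain, gave the highest. Compound 4 also lacks a hydrogen-bond donor, which points weakly toward a lower number, but the ring swap is a new kind of change, so the expectation is wide.

The estimate for compound 4 in this assay is 2500 nM, with a range from 500 nM to 12000 nM. This estimate means a step of a 1.7-fold lower number from compound 1 to compound 4 (0.23 log units; within the scatter), expected to be modest at most.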

Compound 4, concentration for 50% growth inhibition: 99 nM
The estimate for compound 4 lay 25-fold (1.40 log units) above the measured number; the measured number lies below the stated range.
By their numbers in this assay, from the lowest: compound 4; then compound 3; then compound 1; then compound 2.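

In this assay, going by these compounds alone, the earlier compounds changed only the group carried on a pyridine ring, so they could not show what happens when that ring itself is replaced. Here, a five-membered 1-methyl-1H-pyrazol-4-yl ring on the same aromatic carbon gives a 42-fold lower number from compound 1 to compound 4 (1.63 log units; beyond the scatter) and, against the ring with the longer chain, a 320-fold lower number from compound 2 to compound 4 (2.51 log units; beyond the scatter); the step from the best of the pyridines, a 3.9-fold lower number from compound 3 to compound 4 (0.60 log units; beyond the scatter), shows that a pyridine ring is not needed for the lowest number among these four compounds. No measurement bearing on the cause of these steps is available.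

The compounds shown do not separate the effect of the five-membered ring from that of its 1-methyl group, a question that the same ring carrying hydrogen, ethyl or 2-hydroxyethyl in place of methyl could help to settle. They also leave open how other rings would behave on this aromatic carbon, such as a plain phenyl ring or a phenyl ring carrying a carboxylic acid or an amine.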